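Sugar ring exchange on the triazole of compound 2

The source may hold more compounds than are shown below. What is called first, only, known or untested is meant among the compounds shown, and "the series" means these compounds.

Of the compounds shown here, three of the shared core have been measured in a functional assay on A549 cells (Homo sapiens) for cytotoxicity, read by MTT assay, with a stated time of 72 h; a lower number here means a stronger inhibitor, a higher number a weaker inhibitor. Compound 1 `CN1CCN(CCCCCCn2c3c(c4ccccc42)C(=O)c2c[n+]([O-])c4ccccc4c2C3=O)CC1` gives 330 nM. Compound 2 `O=C1c2c[n+]([O-])c3ccccc3c2C(=O)c2c1c1ccccc1n2Cc1cn([C@H]2C[C@H](O)[C@@H](CO)O2)nn1` gives 350 nM. Compound 3 `CCCCN1CCN(CCCCn2c3c(c4ccccc42)C(=O)c2c[n+]([O-])c4ccccc4c2C3=O)CC1` gives 550 nM. Going by the values given here, the only step between measured compounds that differ in one place is a 1.7-fold higher number from compound 1 to compound 3 (0.22 log units; within the scatter). Compound 2 sits among the three numbers with compound 1 as its nearest neighbour and compound 3 as its furthest, and both gaps are within the scatter, so nothing separates it from either.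

Compound 4 `O=C1c2c[n+]([O-])c3ccccc3c2C(=O)c2c1c1ccccc1n2Cc1cn([C@@H]2O[C@H](CO)[C@@H](O)[C@H](O)[C@H]2O)nn1` is not yet measured. It differs from compound 2 in one place: 3,4,5-trihydroxy-6-(hydroxymethyl)oxan-2-yl in place of 4-hydroxy-5-(hydroxymethyl)oxolan-2-yl on an aromatic nitrogen. Among the compounds with values here, no measured pair probes this change. Within the data shown here, the one known step, a 1.7-fold higher number from compound 1 to compound 3 (0.22 log units; within the scatter), concerns a different part of the molecule and was itself within the scatter. Compound 1, compound 2 and compound 3 carry quite different groups on the core yet fall in a narrow band. The expected step is therefore a 1.3-fold higher number from compound 2 to compound 4 (0.11 log units; within the scatter), with no direction asserted beyond the scatter; the added hydroxy groups counted in the change give no basis in these data for a larger shift. Compound 4 is estimated at 450 nM in this assay, within a range of 200 nM to 1100 nM.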

Compound 4, half-maximal inhibitory concentration: 560 nM
Compound 4: middle estimate off by 1.2-fold (0.09 log units), on the low side; measured number inside the range.
By their numbers in this assay, from the lowest: compounds 1, 2, 3 and 4 (each within the scatter of the next).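

At the aromatic nitrogen of the five-membered aromatic ring with 3 nitrogen, 3,4,5-trihydroxy-6-(hydroxymethyl)oxan-2-yl in place of 4-hydroxy-5-(hydroxymethyl)oxolan-2-yl gives a 1.6-fold higher number from compound 2 to compound 4 (0.20 log units; within the scatter) in this assay, the only reading at this position among the compounds shown. Compound 2 and compound 4 therefore cannot be told apart in this read-out, even though the entering group has a six-membered rather than a five-membered ring, 4 rather than 2 hydrogen-bond donors, and 5 rather than 3 defined stereocentres. At this position, then, a sizeable exchange of one sugar ring for another has not produced a step beyond the scatter, which the earlier step, made at a different part of the molecule, could not show.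

Still open, from the compounds shown here alone, is whether a group of another kind on that aromatic nitrogen, such as a primary amine or a carboxylic acid in place of the sugar ring, would separate from compound 2 beyond the scatter. Nothing available accounts for the two sugar-bearing compounds reading alike.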